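The compounds below may be only part of what the source reports. "The series", "measured", "known", "first", "only" and "open" are said of these compounds alone.

Three compounds have been measured so far:

Compound 1, `Cc1csc(N)c1C(=O)c1ccc(Cl)cc1`: 1%
Compound 2, `Nc1sc(-c2ccccc2)c(-c2ccccc2)c1C(=O)c1ccc(Cl)cc1`: 1%
Compound 3, `CC(C)(C)Cc1c(-c2ccncc2)sc(N)c1C(=O)c1ccc(Cl)cc1`: 1%

In an assay on CHO cells for displacement of a labelled ligand from adenosine receptor A1 (Homo sapiens), read by scintillation counting, tested at 10 uM (on this read-out higher numbers stand for more inhibition at the one concentration tested (going by the name of the read-out) and lower numbers for less inhibition), compound 1 gives 1%, compound 2 gives 1%, and compound 3 gives 1%. Compound 3 therefore stands level with compounds 1 and 2 at the digits shown: the nearest of the two is compound 1, with no change at those digits, and the furthest is compound 2, again with no change at those digits, both within the usual scatter. None of the three displaces the labelled ligand to any noticeable degree at the concentration used.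

Compound 4, `CC(C)(C)Cc1c(-c2ccc(F)cc2)sc(N)c1C(=O)c1ccc(Cl)cc1`, has not yet been measured. It differs from compound 3 in a single place: 4-fluorophenyl in place of pyridin-4-yl on an aromatic carbon. The change sits on the five-membered aromatic ring, next to the ring sulfur, while the rest of the molecule, including the neopentyl group and the amino group, is kept.

Among the compounds with values here, no step between two measured compounds is available, so nothing shows how such a swap shifts the read-out. What the three measured values do show is that compounds 1, 2 and 3 all sit at the same very low level in this assay. For compound 4 a step of a number 2 percentage points higher from compound 3 to compound 4 (within the scatter) is expected, that is, none beyond the scatter. Compound 4 is estimated to give 3% in this assay, with a range from 0% to 15%.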

Compound 4, a percentage reported as inhibition, at one concentration (the size of the read-out at that concentration, not a potency): 1%
Compound 4: the middle estimate sits 2 percentage points above what was measured, and the stated range covers the measured number.
By their numbers in this assay, from the lowest: compounds 1, 2, 3 and 4 (each within the scatter of the next).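

Within the data shown here, measured in this assay, this is the first direct comparison at one position, and it gives no change at the digits printed from compound 3 to compound 4 (within the scatter) when 4-fluorophenyl takes the place of pyridin-4-yl on the aromatic carbon next to the ring sulfur. Among these compounds, exchanging a ring that holds a nitrogen and counts one hydrogen-bond acceptor for a carbon-only ring bearing fluorine and counting none therefore leaves the read-out unmoved, but both compounds sit so close to nothing that the result says only that neither ring brings visible displacement at the concentration tested, not that the position is indifferent to what it carries. No measurement is available that would explain this result.

As far as these compounds go, it remains open whether a quite different group on this aromatic carbon, such as a carboxylic acid, a primary amine or a longer alkyl chain, would produce a clear signal in this assay. From the compounds shown here alone, it is equally open whether the exchange of these two rings would make any difference on a compound that does displace the labelled ligand, since a read-out near zero leaves little room for a difference to appear.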